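Replacing the sulfonamide methyl of compound 1 with 4-nitrophenyl

This account rests on a few compounds, and the source may have more. Where it says the series, first, only, none or still open, it means among the compounds named here.

Within the data shown here, compound 1 `CNS(=O)(=O)c1ccc2c(c1)C(n1ccccc1=O)=CC(C)(C)O2` is the one with the lowest number among the two single values in a functional assay with Rattus norvegicus as the target; on this read-out lower numbers stand for an effect already at smaller amounts and higher numbers for an effect only at larger amounts of compound: compound 1 gives 17.8 nM. Its nearest neighbour is compound 2 `CCNS(=O)(=O)c1ccc2c(c1)C(n1ccccc1=O)=CC(C)(C)O2`, which in this assay gives 56.2 nM; the step of a 3.2-fold higher number from compound 1 to compound 2 (0.50 log units; beyond the scatter). Compound 3 `CC1(C)C=C(n2ccccc2=O)c2cc(S(=O)(=O)Nc3ccccc3)ccc2O1` has no single number but several entries, and in this assay compound 3 shows 3.09 nM; 2 nM (2 entries), which is what the several entries of compound 3 in this assay, 3.09 nM; 2 nM (2 entries) records.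

Compound 4 `CC1(C)C=C(n2ccccc2=O)c2cc(S(=O)(=O)Nc3ccc([N+](=O)[O-])cc3)ccc2O1` differs from compound 1 by 4-nitrophenyl in place of methyl on a sulfonamide nitrogen. Among the measured compounds shown here, no measured step covers exactly this change. The step from compound 1 to compound 2 shows that enlarging the group on the sulfonamide nitrogen by a methyl raised the number modestly, while the entries of compound 3 show that an aromatic ring in the same place goes with lower numbers than compound 1. Compound 4 carries such a ring, so a step towards a lower number is expected: compound 4 is estimated at 4 nM, between 1.2 nM and 14 nM, and the expected step is a 4.5-fold lower number from compound 1 to compound 4 (0.65 log units; beyond the scatter).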

Compound 4, half-maximal effective concentration: 2090 nM
For compound 4 the middle estimate is 520-fold (2.72 log units) below the measured one; measured number above the stated range.
By their numbers in this assay, from the lowest: compound 1; then compound 2; then compound 4.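

In this assay, an aromatic ring on the sulfonamide nitrogen does not by itself go with low numbers: 4-nitrophenyl in place of methyl gives a 120-fold higher number from compound 1 to compound 4 (2.07 log units; beyond the scatter), and 4-nitrophenyl in place of ethyl gives a 37-fold higher number from compound 2 to compound 4 (1.57 log units; beyond the scatter). Both steps are much larger than the modest one between the two small chains, so this position can respond far more strongly than those compounds showed. Compound 4 differs from compound 3 only by the nitro group on the phenyl ring, yet its number lies far higher than the entries for the plain ring, which makes what the ring carries decisive here: the several entries of compound 3 in this assay, 3.09 nM; 2 nM (2 entries)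

The compounds shown leave open whether the higher number belongs to the nitro group specifically or to any group at that place on the ring. A methoxy group, a chlorine atom or an amine there would separate these two readings.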